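The source may report more compounds than this note shows. Statements on the series, on what has been measured and on what is new or still open speak of the compounds shown alone.

Measured so far:
- compound 1, `CC(C)c1noc(N2CCC(Oc3cc(N4CCc5cc(C6CCCCC6=O)ccc54)ncn3)CC2)n1`: 48 nM
- compound 2, `CC(C)c1noc(N2CCC(Oc3cc(N4CCc5cc(N6CCCNS6(=O)=O)ccc54)ncn3)CC2)n1`: 24 nM

Compound 2 gives the lower of the two numbers in an assay on CHO cells for agonist activity at Glucose-dependent insulinotropic receptor (Homo sapiens), read by a luciferase reporter and cAMP accumulation, with a stated time of 2 h (a higher number here means that more compound is needed for the effect, a lower number that less compound is needed), but the one step measured, a 2.0-fold lower number from compound 1 to compound 2 (0.30 log units; within the scatter), sits within the scatter, so the two compounds cannot be ordered on the numbers shown.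

Compound 3, `CC(C)c1noc(N2CCC(Oc3cc(N4CCc5cc(N6CCCS6(=O)=O)ccc54)ncn3)CC2)n1`, is the next member. The change from compound 2 is a group of 7 heavy atoms (3 carbon, 1 nitrogen, 2 oxygen, 1 sulfur; one five-membered non-aromatic ring with 2 hetero atoms) in place of a group of 8 heavy atoms (3 carbon, 2 nitrogen, 2 oxygen, 1 sulfur; one six-membered non-aromatic ring with 3 hetero atoms), on an aromatic carbon. The saturated ring attached to the aromatic carbon keeps its sulfonyl group and loses the ring nitrogen that carried the hydrogen, shrinking by one ring atom.

Within the data shown here, only one measured step bears on this position: a 2.0-fold lower number from compound 1 to compound 2 (0.30 log units; within the scatter), which swapped a carbon-only ring for a heteroatom-containing ring and stayed within the scatter. That exchange was larger in kind than the present one and still moved the number little. The expectation for compound 3 in this assay is therefore no step beyond the scatter in either direction, expressed as a 1.3-fold higher number from compound 2 to compound 3 (0.10 log units; within the scatter). Compound 3 is estimated at 30 nM, with a range from 10 nM to 90 nM.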

Compound 3, half-maximal effective concentration: 9.7 nM
Compound 3: middle estimate off by 3.1-fold (0.49 log units), on the high side; measured number outside the range, below it.
By their numbers in this assay, from the lowest: compound 3; then compounds 2 and 1 (each within the scatter of the next).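

Among these compounds, this position is not indifferent to the ring it carries in this assay: replacing the six-membered non-aromatic ring with 3 hetero atoms by the five-membered non-aromatic ring with 2 hetero atoms gives a 2.5-fold lower number from compound 2 to compound 3 (0.39 log units; beyond the scatter), the first step at this aromatic carbon to lie beyond the scatter. Measured against the six-membered ring of carbon only, the same five-membered ring gives a 4.9-fold lower number from compound 1 to compound 3 (0.69 log units; beyond the scatter), which leaves compound 3 with the lowest number of the three, and both of its steps are beyond the scatter. Nothing measured here bears on why the number falls.

The step to compound 3 changes ring size and removes the hydrogen-bond donor together, and the compounds shown do not separate these two changes. A six-membered ring with a sulfonyl group and a single ring nitrogen would isolate ring size, while an open-chain methylsulfonylamino group would test whether the ring is needed at all.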